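A few compounds are considered here, and "the series" means these few. Any claim that something is new, unique, unknown or untested is made for them only; others in the source may bear on it.

Measured compounds:
- compound 1, `Cc1ccccc1C(c1ccccc1)N1CCN(c2ncnc3c2cnn3-c2ccccc2)CC1`: in a functional assay on cells (Rhabdomyosarcoma cell, Homo sapiens) for cytotoxicity (a higher number here means a weaker inhibitor, a lower number a stronger inhibitor), compound 1 gives > 25000 nM, which is a limit of the assay.
- compound 2, `Cc1noc(C)c1C(c1ccccc1)N1CCN(c2ncnc3c2cnn3-c2ccccc2)CC1`: in this assay compound 2 gives > 25000 nM, again a limit.
- compound 3, `N#Cc1cccc(C(c2ccccc2)N2CCN(c3ncnc4c3cnn4-c3ccccc3)CC2)c1`: in this assay compound 3 gives > 25000 nM, also a limit.

Compound 3 therefore stands only at a limit, and the two other values shown are limits as well. The steps among the measured compounds, a step that the two limits leave unreadable from compound 1 to compound 2, a step that the two limits leave unreadable from compound 1 to compound 3 and a step that the two limits leave unreadable from compound 2 to compound 3, are left unreadable in size and direction because of the limit of > 25000 nM in this assay, at which 3 of the 3 values shown sit.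

The compound yet to be measured is compound 4, `c1ccc(-c2ccc(C(c3ccccc3)N3CCN(c4ncnc5c4cnn5-c4ccccc4)CC3)cc2)cc1`. It differs from compound 3 in one place: 4-phenylphenyl in place of 3-cyanophenyl on a saturated chain carbon bound to an amine nitrogen in a ring and an aromatic carbon. Among the compounds with values here, none of the measured steps can be read, so no step size is carried over; what bears on the expectation is that every value shown sits at the same limit. The step from compound 3 to compound 4 is therefore expected to be a step that the limit leaves unreadable from compound 3 to compound 4, that is, nothing beyond the scatter that can be told from a limit. For compound 4 in this assay the estimate is 40000 nM, with a range from 12000 nM to 150000 nM, and most likely the assay again reports only a limit.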

Compound 4, half-maximal inhibitory concentration: > 25000 nM
Compound 4 was reported as a limit (the forecaster's own chance of this, stated with the estimate: 85%); the middle value lies beyond the limit too.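

In this assay compound 4 gives > 25000 nM and this is a limit of the assay. The steps to compound 4 from compound 1, compound 2 and compound 3 cannot be read, because all rest on one limit: (the limit of > 25000 nM in this assay, at which 4 of the 4 values shown sit). The compounds shown leave open whether any group at this place gives a measurable value in this assay.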